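Azetidinylmethoxy pyridines: swapping ethoxy for aminomethyl

This account rests on a few compounds, and the source may have more. Where it says the series, first, only, none or still open, it means among the compounds named here.

Compound 1, `Brc1cncc(OC[C@@H]2CCN2)c1`, gives 0.18 nM in an assay on brain for binding affinity to Neuronal acetylcholine receptor; alpha4/beta2 (Rattus norvegicus), read by radioligand binding; a higher number here means a weaker inhibitor, a lower number a stronger inhibitor.
Compound 2, `Nc1cncc(OC[C@@H]2CCN2)c1`, gives 0.082 nM in this assay.
Compound 3, `CCOc1cncc(OC[C@@H]2CCN2)c1`, gives 0.039 nM in this assay.

Compound 3 has the lowest number of the three; the nearest is compound 2, and compound 1 lies furthest away. The measured steps are a 2.2-fold lower number from compound 1 to compound 2 (0.34 log units; beyond the scatter), a 4.6-fold lower number from compound 1 to compound 3 (0.66 log units; beyond the scatter) and a 2.1-fold lower number from compound 2 to compound 3 (0.32 log units; beyond the scatter), all modest and each beyond the scatter.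

Compound 4, `NCc1cncc(OC[C@@H]2CCN2)c1`, is not yet measured. The change from compound 3 is aminomethyl in place of ethoxy on an aromatic carbon. The step that bears most directly on it is a 2.1-fold lower number from compound 2 to compound 3 (0.32 log units; beyond the scatter), where a group with a hydrogen-bond donor gave way to ethoxy and the number fell; compound 4 brings a donor back, so the reverse direction is expected. The step from compound 3 to compound 4 is therefore estimated as a 2.1-fold higher number from compound 3 to compound 4 (0.31 log units; beyond the scatter), a modest rise in the number. Compound 4 is expected to give about 0.08 nM, within roughly 0.03 nM to 0.25 nM.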

Compound 4, inhibition constant: 4.4 nM
Estimate against measurement, compound 4: 55-fold (1.74 log units) below, and the stated range ends below it.
By their numbers in this assay, from the lowest: compound 3; then compound 2; then compound 1; then compound 4.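

In this assay the change to aminomethyl gives a 110-fold higher number from compound 3 to compound 4 (2.05 log units; beyond the scatter) and a 54-fold higher number from compound 2 to compound 4 (1.73 log units; beyond the scatter) and also a 24-fold higher number from compound 1 to compound 4 (1.39 log units; beyond the scatter) on the same aromatic carbon, so this position, where bromo, amino and ethoxy differed only modestly, can also give large steps. The amino of compound 2 gives a low number, which shows that a nitrogen-bearing group at this place does not by itself bring such a rise; the rise appears only with aminomethyl in compound 4. Nothing measured here accounts for this rise.

The compounds shown leave open whether the step follows the amine of aminomethyl or the carbon that carries it, which hydroxymethyl or methoxymethyl on the same aromatic carbon would help to separate. They also leave open how a dimethylaminomethyl group or a longer aminoethyl chain would fare here.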